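The source may report more compounds than this note shows. Statements on the series, on what has been measured and on what is new or still open speak of the compounds shown alone.

Compound 1, with the structure `O=C(/C=C\c1ccc([N+](=O)[O-])cc1)N1N=C(c2ccncc2)OC1c1c[nH]c2ccccc12`, gives in an ADME assay on PANC-1 cells (Homo sapiens) for cytotoxicity, read by MTT assay, with a stated time of 48 h (a higher number here means a weaker inhibitor of growth, a lower number a stronger inhibitor of growth), only a limit of the assay, > 30 ug/mL.
Compound 2, with the structure `O=C(/C=C\c1cccc(F)c1)N1N=C(c2ccncc2)OC1c1c[nH]c2ccccc12`, gives in this assay likewise only a limit, > 30 ug/mL.

Compound 2 therefore stands at the top end of what this assay reports, without a number of its own. Among the measured compounds shown here, the one measured step, a step that the two limits leave unreadable from compound 1 to compound 2, cannot be read, because both of its ends sit at the limit of > 30 ug/mL in this assay, at which 2 of the 2 values shown sit. Nothing in these two values says whether a change on the chain attached to the carbonyl carbon moves the read-out at all.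

Compound 3, with the structure `O=C(/C=C/c1c(Cl)cccc1Cl)N1N=C(c2ccncc2)OC1c1c[nH]c2ccccc12`, is not yet measured. It differs from compound 2 by 2-(2,6-dichlorophenyl)ethenyl in place of 2-(3-fluorophenyl)ethenyl on a carbonyl carbon. For the measured compounds named here, the only step that touches this part of the molecule is the unreadable one from compound 1 to compound 2, so no direction or size can be drawn from it. The expectation for compound 3 is therefore that it again reaches the limit rather than a number, and the step that the limit leaves unreadable from compound 2 to compound 3 is expected to be no more than the scatter. Compound 3 is estimated at 40 ug/mL, with a range from 15 ug/mL to 100 ug/mL.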

Compound 3, concentration for 50% growth inhibition: > 30 ug/mL
Compound 3 was reported as a limit; the forecaster's own chance of this, stated with the estimate: 75%; the middle value does not contradict the limit.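

The steps from compound 1 to compound 3 and from compound 2 to compound 3 cannot be read, because all three compounds give only a limit in this assay, not a number: the limit of > 30 ug/mL in this assay, at which 3 of the 3 values shown sit. The compounds shown leave open whether any change to the group on the carbonyl carbon moves growth inhibition at all, and in which direction.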